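The source may report more compounds than this note shows. Statements on the series, on what has been measured and on what is new or still open speak of the compounds shown alone.

Measured in a functional assay on cells (Cancer cell lines, Homo sapiens) for inhibition, with a stated time of 48 h; a lower number here means a stronger inhibitor of growth, a higher number a weaker inhibitor of growth:
Compound 1 `CN(C)c1ccc2[nH]c(Cl)c(/C=C3/C(=O)Nc4ccc(O)cc43)c2c1`: 3800 nM
Compound 2 `CN(C)c1ccc2[nH]c(Cl)c(/C=C3/C(=O)N(C)c4ccc(O)cc43)c2c1`: 6030 nM
Compound 3 `COc1cc2c(/C=C3/C(=O)N(C)c4ccccc43)c[nH]c2cc1C`: 1070 nM

Compound 3 has the lowest of the three numbers, and its gaps to both others lie beyond the scatter. Compound 4 `COc1cc2c(/C=C3/C(=O)N(C)c4ccc(O)cc43)c[nH]c2cc1C` differs from it by one change: hydroxy in place of hydrogen on an aromatic carbon. For the measured compounds named here, no measured step isolates this change. Going by the values given here, the only step available, a 1.6-fold higher number from compound 1 to compound 2 (0.20 log units; within the scatter), concerns methyl in place of hydrogen on an amide-type nitrogen in a ring and lies within the scatter. Compound 1 at 3800 nM and compound 2 at 6030 nM already carry the hydroxy and read higher, but their cores also differ elsewhere. A modest rise in this assay is therefore expected, with wide uncertainty. The expected change is a 1.7-fold higher number from compound 3 to compound 4 (0.23 log units; within the scatter). For compound 4 the estimate is 1800 nM, with an expected range of 600 nM to 5500 nM.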

Compound 4, concentration for 50% growth inhibition: 3720 nM
Estimate against measurement, compound 4: 2.1-fold (0.32 log units) below; the range from low to high includes it.
By their numbers in this assay, from the lowest: compound 3; then compounds 4, 1 and 2 (each within the scatter of the next).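

Hydroxy in place of hydrogen on this aromatic carbon gives a 3.5-fold higher number from compound 3 to compound 4 (0.54 log units; beyond the scatter) in this assay, and this step lies beyond the scatter. For the compounds shown here, the earlier compounds all carried or lacked the hydroxy alongside other differences in their cores, so this is the first pair to isolate the change, and on this core the hydroxy goes with a weaker inhibitor of growth. No supporting measurement is available to explain this rise.

The compounds shown leave open how an amine or a carboxylic acid at this position would read. They also leave open whether hydroxy brings a similar step on the core of compound 1.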